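From Fluoro to Ethyl on the Pendant Aryl Ring

The source may report more compounds than this note shows. Statements on the series, on what has been measured and on what is new or still open speak of the compounds shown alone.

Of the compounds shown here, three sharing one core have been measured in an ADME assay (liver) for metabolic stability, with Liver microsome (Canis lupus familiaris) as the target, read by LC-MS, using microsomes, with a stated time of 30 min, tested at 4 uM; on this read-out higher numbers stand for a more stable compound and lower numbers for a less stable compound. Compound 1 `Cc1nc(N2CCN(C)CC2)c2nc(-c3cccc(C(F)(F)F)c3)n(C3CCOCC3)c2n1` gives 44% in this assay, compound 2 `COc1ccccc1-c1nc2c(N3CCN(C)CC3)nc(C)nc2n1C1CCOCC1` gives 36%, and compound 3 `Cc1nc(N2CCN(C)CC2)c2nc(-c3ccccc3F)n(C3CCOCC3)c2n1` gives 21%. Compound 3 thus stands lowest of the three: its nearest neighbour is compound 2, and the gap to compound 1 is the widest. The step of a number 8 percentage points lower from compound 1 to compound 2 (within the scatter) lies within the scatter, whereas a number 23 percentage points lower from compound 1 to compound 3 (beyond the scatter) and a number 15 percentage points lower from compound 2 to compound 3 (beyond the scatter) both lie beyond it.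

Compound 4 `CCc1ccccc1-c1nc2c(N3CCN(C)CC3)nc(C)nc2n1C1CCOCC1` differs from compound 3 in one place: ethyl in place of fluoro on an aromatic carbon. Of the measured steps, only a number 15 percentage points lower from compound 2 to compound 3 (beyond the scatter) touches the same position of the pendant ring, and it shows that exchanging methoxy for fluoro there lowered the read-out by a modest amount. Going by the values given here, no measured step involves an ethyl group, so the data give no direct guide to its effect. The two earlier changes at the pendant ring moved the read-out by modest amounts at most, so a step of similar size or none beyond the scatter is expected in this assay. Compound 4 is therefore estimated at 25%, between 10% and 42%, which would mean an expected step of a number 4 percentage points higher from compound 3 to compound 4 (within the scatter).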

Compound 4, percent of the compound remaining: 74%
For compound 4 the middle estimate is 49 percentage points below the measured one, outside the stated range (above it).
By their numbers in this assay, from the lowest: compound 3; then compounds 2 and 1 (each within the scatter of the next); then compound 4.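

In this assay, going by these compounds alone, the substituent on the pendant ring, on an aromatic carbon ortho to a large group, proves able to move the read-out far more than the earlier compounds suggested: ethyl in place of fluoro gives a number 53 percentage points higher from compound 3 to compound 4 (beyond the scatter) and ethyl in place of methoxy gives a number 38 percentage points higher from compound 2 to compound 4 (beyond the scatter), both large steps where the earlier changes on this ring were modest at most. The 2-ethylphenyl group also exceeds the trifluoromethyl-bearing ring, with a number 30 percentage points higher from compound 1 to compound 4 (beyond the scatter), which makes compound 4 the highest of the four, with its steps to all the others beyond the scatter. Nothing in the information at hand accounts for this jump.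

The compounds shown leave open whether the result depends on ethyl itself or would also appear with a methyl, an isopropyl or a cyclopropyl group in the same place. They also leave open whether a longer chain or an amine there would keep the read-out as high, and whether ethyl on another carbon of the ring would do the same.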